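Methyl in Place of Ethoxy on a Shared Core

The compounds below may be only part of what the source reports. "The series", "measured", "known", "first", "only" and "open" are said of these compounds alone.

Measured so far in an assay on CHO cells for displacement of a labelled ligand from adenosine receptor A1 (Homo sapiens), read by radioligand binding; a higher number here means a weaker inhibitor, a lower number a stronger inhibitor:
compound 1, `CCOc1cccc2cc(-c3ccc(OC)cc3OC)c(=O)oc12`: > 100000 nM
compound 2, `CCOc1cccc2cc(-c3cc(OC)c(OC)c(OC)c3)c(=O)oc12`: > 100000 nM
compound 3, `Cc1cccc2cc(-c3ccc([N+](=O)[O-])cc3)c(=O)oc12`: > 100000 nM

All three compounds share one core and differ in the groups attached to it. In this assay compound 2 gives only the limit of the assay, so no number is known for it. The same holds for compound 1, which also sits at the limit. Compound 3 sits at the limit as well; in short, (the limit of > 100000 nM in this assay, at which 3 of the 3 values shown sit).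

Compound 4, `COc1cc(-c2cc3cccc(C)c3oc2=O)cc(OC)c1OC`, has not yet been measured. It differs from compound 2 by methyl in place of ethoxy on an aromatic carbon. Going by the values given here, no step between two measured compounds is available, so the expectation rests on the fact that every measured compound, including compound 3, which already carries a methyl at this place, sits at the limit. The step that the limit leaves unreadable from compound 2 to compound 4 is therefore expected to be none beyond the scatter, with the result most likely again a limit. For compound 4 the expected value is 150000 nM, in a range from 50000 nM to 500000 nM.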

Compound 4, inhibition constant: > 60000 nM
Compound 4 gave a limit, no number; the forecaster's own chance of this, stated with the estimate: 85%; the middle value is on the limit's open side.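

Going by these compounds alone, compound 2 and compound 4 each gave only a limit in this assay, not a number, and no step between them can be read. The compounds shown leave open whether methyl in place of ethoxy changes anything, and how strong an inhibitor any of them is.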